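A few compounds are considered here, and "the series" means these few. Any claim that something is new, unique, unknown or untested is made for them only; others in the source may bear on it.

In a functional assay on A549 cells (Homo sapiens) for cytotoxicity, read by MTT assay (on this read-out higher numbers stand for weaker inhibition and lower numbers for stronger inhibition), compound 3 `COc1cccc(-c2cc(-c3c(O)c4ccccc4oc3=O)nc(S)n2)c1` gives 10200 nM. That number lies within the usual scatter of compound 1 `COc1cccc(-c2cc(-c3c(O)c4ccccc4oc3=O)nc(O)n2)c1`, which gives 5550 nM. Both lie above compound 2 `O=c1oc2ccccc2c(O)c1-c1cc(-c2ccc(F)cc2)nc(O)n1`, which gives 2390 nM, so compound 3 sits at the weak end of this small set.

The next compound, compound 4 `O=c1oc2ccccc2c(O)c1-c1cc(-c2ccc(F)cc2)nc(S)n1`, keeps the sulfanyl group of compound 3 and carries 4-fluorophenyl in place of 3-methoxyphenyl on an aromatic carbon.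

Within the data shown here, two measured steps bear on this change. The same swap, made with a hydroxy group in place of the sulfanyl group, gave a 2.3-fold lower number from compound 1 to compound 2 (0.37 log units; beyond the scatter). Among the measured compounds shown here, this is the closest precedent, though it is a single modest example and the swap has not yet been measured with the sulfanyl group present. The other step, sulfanyl in place of hydroxy, gave a 1.8-fold higher number from compound 1 to compound 3 (0.26 log units; within the scatter), so that exchange shows no clear shift of its own in this assay. If the swap carries over, a modest move towards a lower number, and so stronger inhibition, is the reasonable expectation.

The expected change is a 2.3-fold lower number from compound 3 to compound 4 (0.37 log units; beyond the scatter). For compound 4 the estimated value is 4400 nM, with an expected range from 2200 nM to 9000 nM.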

Compound 4, half-maximal inhibitory concentration: 21100 nM
Compound 4: middle estimate off by 4.8-fold (0.68 log units), on the low side; the measured number lies above the stated range.
By their numbers in this assay, from the lowest: compound 2; then compounds 1 and 3 (each within the scatter of the next); then compound 4.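

In this assay, the effect of placing 4-fluorophenyl where 3-methoxyphenyl stood depends on the group that shares the ring with it: with sulfanyl present the swap gives a 2.1-fold higher number from compound 3 to compound 4 (0.32 log units; beyond the scatter), which runs opposite to its direction with hydroxy present: the same change on two cores in this assay, a 2.3-fold lower number (0.37 log units; beyond the scatter) from compound 1 to compound 2 and a 2.1-fold higher number (0.32 log units; beyond the scatter) from compound 3 to compound 4, 4.8-fold (0.68 log units) apart, beyond the scatter of two such steps. The exchange of hydroxy for sulfanyl, which showed no clear shift with 3-methoxyphenyl in place, gives an 8.8-fold higher number from compound 2 to compound 4 (0.95 log units; beyond the scatter) with 4-fluorophenyl in place, so its size also depends on the partner group: the same change on two cores in this assay, a 1.8-fold higher number (0.26 log units; within the scatter) from compound 1 to compound 3 and an 8.8-fold higher number (0.95 log units; beyond the scatter) from compound 2 to compound 4, 4.8-fold (0.68 log units) apart, beyond the scatter of two such steps. Across these four compounds, then, the two sites do not act independently, and a step measured on one core cannot simply be added to another.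

Going by these compounds, four compounds make only one such square, so it remains open whether this dependence extends to other groups, such as an amine in place of the hydroxy or sulfanyl group, or a plain phenyl or 4-chlorophenyl in place of the aryl group. The numbers also come from a single cell line and do not show why the two sites depend on each other.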